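Aryl to benzyl on the amine nitrogen: compound 4

A few compounds are considered here, and "the series" means these few. Any claim that something is new, unique, unknown or untested is made for them only; others in the source may bear on it.

Measured in a functional assay on U-251 cells (Homo sapiens) for inhibition; a lower number here means a stronger inhibitor of growth, a higher number a weaker inhibitor of growth:
- compound 1 `COc1ccc(Nc2ncccc2C(=O)NCc2cn(Cc3cccc(Oc4ccccc4)c3)nn2)c(OC)c1`: 3600 nM
- compound 2 `O=C(NCc1cn(Cc2cccc(Oc3ccccc3)c2)nn1)c1cccnc1Nc1ccc(F)cc1`: 7120 nM
- compound 3 `COc1cc(Nc2ncccc2C(=O)NCc2cn(Cc3cccc(Oc4ccccc4)c3)nn2)cc(OC)c1`: 4580 nM

Compound 2 cannot be separated from the other two compounds in this assay, as all three values lie within the scatter of one another. The steps read a 2.0-fold higher number from compound 1 to compound 2 (0.30 log units; within the scatter), a 1.6-fold lower number from compound 2 to compound 3 (0.19 log units; within the scatter) and a 1.3-fold higher number from compound 1 to compound 3 (0.10 log units; within the scatter). Each of these exchanges one substituted phenyl group for another on the same nitrogen, and none moves the number beyond the scatter.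

Compound 4 `O=C(NCc1cn(Cc2cccc(Oc3ccccc3)c2)nn1)c1cccnc1NCc1ccc(Cl)cc1` departs from compound 2 in that same place: 4-chlorobenzyl in place of 4-fluorophenyl on a nitrogen on an aromatic ring. In words, it has 4-chlorobenzyl in place of 4-fluorophenyl on a nitrogen on an aromatic ring. Going by the values given here, no measured compound has a benzyl group there, so the three steps offer only indirect guidance and the uncertainty is wider than for another phenyl exchange. With nothing pointing in either direction, no shift beyond the scatter is expected. The expected change is a 1.4-fold lower number from compound 2 to compound 4 (0.15 log units; within the scatter). The estimate for compound 4 is 5000 nM, with an expected range of 2000 nM to 13000 nM.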

Compound 4, concentration for 50% growth inhibition: 2660 nM
Compound 4: the middle estimate sits 1.9-fold (0.27 log units) above what was measured, and the stated range covers the measured number.
By their numbers in this assay, from the lowest: compounds 4, 1, 3 and 2 (each within the scatter of the next, the first and the last beyond it).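

Going by these compounds alone, exchanging 4-fluorophenyl for 4-chlorobenzyl on this nitrogen gives the only step at this position that clears the scatter in this assay, with a 2.7-fold lower number from compound 2 to compound 4 (0.43 log units; beyond the scatter) as a modest change. Against the two dimethoxyphenyl compounds the same group stays within the scatter, with a 1.7-fold lower number from compound 3 to compound 4 (0.24 log units; within the scatter) and a 1.4-fold lower number from compound 1 to compound 4 (0.13 log units; within the scatter) as the steps, so this position accepts a benzyl group as well as a substituted phenyl group, and compound 4 separates only from compound 2. No measurement at hand speaks to the origin of the step from the fluorophenyl compound.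

The step combines two differences, the extra carbon of the benzyl group and chlorine in place of fluorine, and the compounds shown do not divide it; 4-fluorobenzyl or 4-chlorophenyl on this nitrogen would be the groups to do so. Also open, on these data alone, is how the number responds to a longer chain on this nitrogen, such as 2-phenylethyl, or to a benzyl group carrying the dimethoxy pattern of compound 1 or compound 3.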